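A few compounds are considered here, and "the series" means these few. Any claim that something is new, unique, unknown or untested is made for them only; others in the source may bear on it.

Measured compounds:
- compound 2 `N#C[Se]c1ccc(NC(=O)CCCC(=O)O)cc1`, a functional assay on HepG2 cells (Homo sapiens) for cytotoxicity, read by MTT assay, with a stated time of 48 h; on this read-out lower numbers stand for stronger inhibition and higher numbers for weaker inhibition: 7000 nM
- compound 1 `N#C[Se]c1ccc(NC(=O)CCC(=O)O)cc1`, "not active" (no number reported) in this assay

Compound 2 holds the only numerical result in this set; in this assay compound 2 gives 7000 nM. Compound 1 is recorded in this assay as "not active" (no number reported), with no number attached, so nothing can be said about the size of any step between the two.

Compound 3 `N#C[Se]c1ccc(NC(=O)/C=C\C(=O)O)cc1` is the next compound in line and is still to be measured. Its difference from compound 2 is 2-carboxyethenyl in place of 3-carboxypropyl on a carbonyl carbon. The change shortens the chain and adds a second double bond outside aromatic rings, so the shape of the acid-bearing arm is altered on both counts. Among the compounds with values here, no step between two measured compounds is available to calibrate the effect of such a change.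

The expectation for compound 3 is therefore a modest weakening, estimated as a 2.1-fold higher number from compound 2 to compound 3 (0.33 log units; beyond the scatter), because compound 1 gives "not active" (no number reported) with its shorter arm. Compound 3 is expected to land near 15000 nM, within a range of 5000 nM to 50000 nM, with a real chance that only a limit is reported.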

Compound 3, half-maximal inhibitory concentration: 5000 nM
Estimate against measurement, compound 3: 3.0-fold (0.48 log units) above; low and high end bracket the measured number.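

In this assay, within the data shown here, putting 2-carboxyethenyl in place of 3-carboxypropyl on a carbonyl carbon gives a 1.4-fold lower number from compound 2 to compound 3 (0.15 log units; within the scatter), the first step at this position that can be read at all, and it shows that the arm can be shortened and given a second double bond outside aromatic rings with no difference that stands clear of the scatter. Compound 1 is recorded as "not active" (no number reported), so its steps to the other two compounds cannot be read, but compound 3 now shows that a shorter arm does not always come with the absence of a number, and compound 1 stands as the one case against any simple link between a shorter arm and a missing number. No measurement of any property of these arms accompanies the result, and the data offer no explanation for it.

Going by these compounds, whether the carboxylic acid at the end of the arm is needed stays open, as neither a methyl ester nor a primary amide appears in its place. Also open, on these data alone, are a longer chain on the same carbonyl carbon and any change to the shared core, which is the same in all three compounds.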